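This account rests on a few compounds, and the source may have more. Where it says the series, first, only, none or still open, it means among the compounds named here.

Measured in an assay on CHO cells for displacement of a labelled ligand from Substance-P receptor (Homo sapiens), in the presence of a further agent that is not named here; on this read-out higher numbers stand for weaker inhibition and lower numbers for stronger inhibition:
Compound 1, `C[C@@H](O[C@H]1CN2C(=O)C=C(c3ccc(C#N)cc3)CC2[C@@H]1c1ccc(F)cc1)c1cc(C(F)(F)F)cc(C(F)(F)F)c1`, gives 53 nM.
Compound 2, `Cc1cc(C2=CC(=O)N3C[C@H](O[C@H](C)c4cc(C(F)(F)F)cc(C(F)(F)F)c4)[C@@H](c4ccc(F)cc4)C3C2)ccn1`, gives 34 nM.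
Compound 3, `C[C@@H](O[C@H]1CN2C(=O)C=C(c3cnn(Cc4ccccc4)c3)CC2[C@@H]1c1ccc(F)cc1)c1cc(C(F)(F)F)cc(C(F)(F)F)c1`, gives 66 nM.

Compound 3 has the highest of the three numbers, but every step to it lies within the scatter: a 1.2-fold higher number from compound 1 to compound 3 (0.10 log units; within the scatter) and a 1.9-fold higher number from compound 2 to compound 3 (0.29 log units; within the scatter). Compound 4, `CCc1noc(C2=CC(=O)N3C[C@H](O[C@H](C)c4cc(C(F)(F)F)cc(C(F)(F)F)c4)[C@@H](c4ccc(F)cc4)C3C2)n1`, differs from compound 3 by 3-ethyl-1,2,4-oxadiazol-5-yl in place of 1-benzyl-1H-pyrazol-4-yl on a double-bonded ring carbon. All three measured steps change this same position, and none of them, a 1.6-fold lower number from compound 1 to compound 2 (0.19 log units; within the scatter) included, moves beyond the scatter. On that basis the expected step from compound 3 to compound 4 in this assay is a 1.1-fold lower number from compound 3 to compound 4 (0.04 log units; within the scatter), with no direction beyond the scatter predicted. Compound 4 is therefore estimated at 60 nM, within a range from 20 nM to 180 nM.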

Compound 4, half-maximal inhibitory concentration: 27 nM
Compound 4: middle estimate off by 2.2-fold (0.35 log units), on the high side; low and high end bracket the measured number.
By their numbers in this assay, from the lowest: compounds 4, 2, 1 and 3 (each within the scatter of the next, the first and the last beyond it).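

In this assay, this position gives its first step beyond the scatter, a 2.4-fold lower number from compound 3 to compound 4 (0.39 log units; beyond the scatter), when 3-ethyl-1,2,4-oxadiazol-5-yl, with fewer heavy atoms, replaces 1-benzyl-1H-pyrazol-4-yl. The same group stays within the scatter of the other two, with a 1.3-fold lower number from compound 2 to compound 4 (0.10 log units; within the scatter) and a 2.0-fold lower number from compound 1 to compound 4 (0.29 log units; within the scatter), so the step separates it only from the benzyl-bearing group. Nothing measured here accounts for this step.

The compounds shown leave open whether a propyl chain or an amine in place of the ethyl would move the number, and whether the step follows the loss of the benzyl or the change of ring.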